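Sulfamoyl in Place of Acetyl on a Weak Series

The source may hold more compounds than are shown below. What is called first, only, known or untested is meant among the compounds shown, and "the series" means these compounds.

Compound 1 `O=C(O)c1cnc2cc(S(=O)(=O)O)ccc2c1O` gives 2140000 nM
Compound 2 `O=C(O)c1cnc2cc(O)ccc2c1O` gives 490000 nM
Compound 3 `CC(=O)c1ccc2c(O)c(C(=O)O)cnc2c1` gives 912000 nM

In an assay on isolated protein with malate dehydrogenase, mitochondrial (Sus scrofa) as the target (on this read-out lower numbers stand for stronger inhibition and higher numbers for weaker inhibition), compound 3 stands second highest of the three numbers, separated from compound 2 by a gap within the scatter and from compound 1 by a gap beyond it. Compound 4 `NS(=O)(=O)c1ccc2c(O)c(C(=O)O)cnc2c1` arises from compound 3 by the change (sulfamoyl in place of acetyl on an aromatic carbon). For the measured compounds named here, two measured steps bear on it. The step of a 2.3-fold lower number from compound 1 to compound 3 (0.37 log units; beyond the scatter) runs in the opposite sense to the present change, and the step of a 4.4-fold lower number from compound 1 to compound 2 (0.64 log units; beyond the scatter) points the same way, while a 1.9-fold higher number from compound 2 to compound 3 (0.27 log units; within the scatter) stayed within the scatter. Compound 4 is therefore expected to move modestly upward, by a 1.6-fold higher number from compound 3 to compound 4 (0.22 log units; within the scatter), toward compound 1. The estimate for compound 4 is 1500000 nM, with a range from 600000 nM to 4000000 nM.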

Compound 4, half-maximal inhibitory concentration: 955000 nM
Compound 4: the middle estimate sits 1.6-fold (0.20 log units) above what was measured; the measured number falls inside the stated range.
By their numbers in this assay, from the lowest: compounds 2, 3 and 4 (each within the scatter of the next); then compound 1.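

In this assay, sulfamoyl on this aromatic carbon cannot be told apart from acetyl, a 1.0-fold higher number from compound 3 to compound 4 (0.02 log units; within the scatter), or from hydroxy, a 1.9-fold higher number from compound 2 to compound 4 (0.29 log units; within the scatter). Only the sulfo group stands apart: amino in place of hydroxy on the sulfonyl sulfur gives a 2.2-fold lower number from compound 1 to compound 4 (0.35 log units; beyond the scatter), so a sulfonyl unit at this position does not by itself set the number. Nothing at hand explains why the sulfo group differs. From the compounds shown here alone, whether an amine, a methylsulfonyl group or a longer chain on the sulfamoyl nitrogen would shift the number beyond the scatter remains open.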